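Fluorine to Dichloro on the Aniline Ring

The source may report more compounds than this note shows. Statements on the series, on what has been measured and on what is new or still open speak of the compounds shown alone.

Of the compounds shown here, three built on one shared core have been tested in a functional assay on MGC-803 cells (Homo sapiens) for inhibition, read by MTT assay, with a stated time of 72 h; on this read-out lower numbers stand for stronger inhibition and higher numbers for weaker inhibition. Compound 1 `C=CC(=O)Nc1cccc(NC(=O)CSc2nc(Nc3cccc(Cl)c3)c3ccccc3n2)c1` gives 7830 nM. Compound 2 `C=CC(=O)Nc1cccc(NC(=O)CSc2nc(Nc3cccc(OC)c3)c3ccccc3n2)c1` gives 24200 nM, and compound 3 `C=CC(=O)Nc1cccc(NC(=O)CSc2nc(Nc3ccc(F)cc3)c3ccccc3n2)c1` gives 8290 nM. Compound 3 and compound 1 lie within the usual scatter of each other, since a 1.1-fold higher number from compound 1 to compound 3 (0.02 log units; within the scatter). Against compound 2 the gap is real: a 2.9-fold lower number from compound 2 to compound 3 (0.47 log units; beyond the scatter). So compound 3 and compound 1 together occupy the lower numbers of this small set, while compound 2 stands apart with a weaker result.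

Compound 4 `C=CC(=O)Nc1cccc(NC(=O)CSc2nc(Nc3ccc(Cl)c(Cl)c3)c3ccccc3n2)c1` has not yet been measured in this assay. The change from compound 3 is 3,4-dichlorophenyl in place of 4-fluorophenyl on a nitrogen on an aromatic ring. Two measured steps speak to it. Swapping the chloro of the 3-chlorophenyl group for methoxy gave a 3.1-fold higher number from compound 1 to compound 2 (0.49 log units; beyond the scatter), a modest loss. Moving from the 3-chlorophenyl group to the 4-fluorophenyl group gave a 1.1-fold higher number from compound 1 to compound 3 (0.02 log units; within the scatter), no change beyond the scatter. Chloro and fluoro on this group have therefore given similar numbers, and no compound with a 3,4-dichlorophenyl group has been measured. The expected step in this assay is small, perhaps a slight gain: a 1.4-fold lower number from compound 3 to compound 4 (0.14 log units; within the scatter) is the estimate. Compound 4 is thus expected at 6000 nM, within a range from 2500 nM to 15000 nM.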

Compound 4, half-maximal inhibitory concentration: > 50000 nM
Compound 4: no number, only a limit (the forecaster's own chance of this, stated with the estimate: 0%); middle value at least 8.3-fold (0.92 log units) from the limit.
By their numbers in this assay, from the lowest: compounds 1 and 3 (each within the scatter of the next); then compound 2. At a limit, above all of these: compound 4.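

In this assay compound 4 reads > 50000 nM, which is a limit of the assay and not a number. The earlier compounds shown here showed chloro and fluoro giving similar results on this aniline ring, with methoxy costing only a modest amount, whereas 3,4-dichlorophenyl in place of 4-fluorophenyl gives an at least 6.0-fold higher number from compound 3 to compound 4 (0.78 log units; beyond the scatter), and in place of 3-methoxyphenyl it gives an at least 2.0-fold higher number from compound 2 to compound 4 (0.31 log units; beyond the scatter), so the group on this nitrogen can matter far more than those compounds suggested. The sharpest comparison is the addition of one chloro in place of hydrogen on an aromatic carbon, which gives an at least 6.3-fold higher number from compound 1 to compound 4 (0.80 log units; beyond the scatter): a single added atom separates a compound with a measured number from one at the limit.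

Going by these compounds, since compound 4 has only a limit, the true size of these steps stays unknown, and a single dichloro compound cannot tell whether the loss belongs to this particular pair of chloro groups or to any second group on the ring. On these data alone, how a plain phenyl group, or a ring carrying an amine or a carboxylic acid, would read in this assay also remains open.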